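Cyclopropylcarbamoyl Replaces Fluoro on a Kinase Inhibitor Core

This account rests on a few compounds, and the source may have more. Where it says the series, first, only, none or still open, it means among the compounds named here.

Compound 1 `Cc1ccc2c(c1)CC(c1nc3ccc(-c4cn[nH]c4)cc3c(=O)[nH]1)CO2`: 6 nM
Compound 2 `O=c1[nH]c(C2COc3ccc(F)cc3C2)nc2ccc(-c3cn[nH]c3)cc12`: 3 nM

In an assay on isolated protein for inhibition of Rho-associated protein kinase 2 (Homo sapiens), read by HTRF (on this read-out higher numbers stand for weaker inhibition and lower numbers for stronger inhibition), compound 2 stands lowest of the two numbers, but the step of a 2.0-fold lower number from compound 1 to compound 2 (0.30 log units; within the scatter) lies within the scatter, so the two compounds are not separated. Compound 3 `O=C(NC1CC1)c1ccc2c(c1)CC(c1nc3ccc(-c4cn[nH]c4)cc3c(=O)[nH]1)CO2` differs from compound 2 by cyclopropylcarbamoyl in place of fluoro on an aromatic carbon. Among the compounds with values here, the only measured step, a 2.0-fold lower number from compound 1 to compound 2 (0.30 log units; within the scatter), exchanges two small groups and says little about a larger group entering at that carbon. With nothing bearing directly on this change, the expected step of a 2.0-fold higher number from compound 2 to compound 3 (0.30 log units; within the scatter) is small with no clear direction. Compound 3 is therefore estimated at 6 nM, between 1.5 nM and 25 nM.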

Compound 3, half-maximal inhibitory concentration: 1 nM
Beside the measured number, compound 3's estimate is 6.0-fold (0.78 log units) above it, outside the stated range (below it).
By their numbers in this assay, from the lowest: compound 3; then compounds 2 and 1 (each within the scatter of the next).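

In this assay this aromatic carbon takes a far larger group than methyl or fluoro with no loss: cyclopropylcarbamoyl gives a 3.0-fold lower number from compound 2 to compound 3 (0.48 log units; beyond the scatter) and a 6.0-fold lower number from compound 1 to compound 3 (0.78 log units; beyond the scatter) on the two smaller groups. The position therefore accepts a group bringing a three-membered ring, a hydrogen-bond donor and a hydrogen-bond acceptor, and the number falls rather than rises. Nothing measured here explains this gain. Still open, going by these compounds, is whether the amide hydrogen or the cyclopropyl ring matters more, and how a primary amide, a methyl amide or a carboxylic acid would read at this carbon.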